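Three compounds, two limits, one new aryl group

The source may report more compounds than this note shows. Statements on the series, on what has been measured and on what is new or still open speak of the compounds shown alone.

Compound 3 `COC(=O)c1cc(=O)c2cc(NC(=O)Nc3ccc(Cl)c(Cl)c3)ccc2[nH]1` carries a methyl ester on the shared core and a 3,4-dichlorophenyl group on its amide-type nitrogen. Its closest companion, compound 2 `COC(=O)c1cc(=O)c2cc(NC(=O)Nc3ccc(Cl)c(C(F)(F)F)c3)ccc2[nH]1`, differs only in having trifluoromethyl where compound 3 has one chloro on an aromatic carbon. Compound 1 `COc1cc(OC)c2c(=O)cc(C(=O)Nc3ccc(Oc4ccc([N+](=O)[O-])cc4)cc3)[nH]c2c1` differs more widely from both.

In a functional assay on UoC-B1 cells (Homo sapiens) for antiproliferative activity, with a stated time of 72 h (a lower number here means that less compound is needed, a higher number that more compound is needed for the effect), compound 3 gives only a limit, > 6350 nM. In this assay compound 2 likewise gives only a limit, > 6350 nM. For compound 1 this assay reports "not determined" (no result reported). The step that the two limits leave unreadable from compound 2 to compound 3 thus cannot be read, since both of its ends sit at the same limit (the limit of > 6350 nM in this assay, at which 2 of the 3 values shown sit). Compound 3 therefore stands nowhere on a scale of numbers: it is simply one of two compounds whose potency was too weak to be measured.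

Compound 4 `COC(=O)c1cc(=O)c2cc(NC(=O)Nc3cccc(C(C)=O)c3)ccc2[nH]1` introduces (3-acetylphenyl in place of 3,4-dichlorophenyl on an amide-type nitrogen). Among the compounds with values here, no measured step bears readably on this exchange, as the single step from compound 2 to compound 3 yielded no size. Accordingly, no step beyond the scatter can be expected in either direction, and another limit is the most likely outcome. Compound 4 is estimated at 9000 nM, within 2000 nM to 40000 nM, corresponding to an expected step that the limit leaves unreadable from compound 3 to compound 4.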

Compound 4, half-maximal effective concentration: > 8080 nM
Compound 4 was reported as a limit (the forecaster's own chance of this, stated with the estimate: 70%); the middle value is on the limit's open side.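

Compound 4, like compound 3, gives only a limit in this assay and not a number, so no step can be read for 3-acetylphenyl in place of 3,4-dichlorophenyl. The compounds shown leave open whether any aryl group on the amide-type nitrogen of the shared core gives a measurable value in this assay.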